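Diethylamino for pyrrolidin-1-yl: an expected small step

The compounds below may be only part of what the source reports. "The series", "measured", "known", "first", "only" and "open" are said of these compounds alone.

In an ADME assay on HMEC-1 cells (Homo sapiens) for cytotoxicity, read by MTT assay (on this read-out higher numbers stand for weaker inhibition and lower numbers for stronger inhibition), compound 1 `Cc1c(CN2CCCC2)cc(-c2ccc(Cl)cc2)n1Nc1ccnc2cc(Cl)ccc12` gives 7180 nM as its value. Compound 2 `Cc1cc(CNC[C@@H]2CCCN3CCCC[C@H]23)c(C)n1Nc1ccnc2cc(Cl)ccc12` reads 5400 nM and lies within the scatter of compound 1. Compound 3 `Cc1c(CNCC[C@@H]2CCCN3CCCC[C@H]23)cc(-c2ccccc2)n1Nc1ccnc2cc(Cl)ccc12` reads 14600 nM and stands higher than compound 1 by a margin just beyond the scatter. Compound 4 `CCN(CC)Cc1cc(-c2ccc(Cl)cc2)n(Nc2ccnc3cc(Cl)ccc23)c1C` has not yet been measured. It carries diethylamino in place of pyrrolidin-1-yl on a saturated chain carbon bound to an aromatic carbon and otherwise matches compound 1. For the measured compounds named here, no measured pair isolates this change. The expected step of a 1.0-fold lower number from compound 1 to compound 4 (0.01 log units; within the scatter) stays within the scatter, with no direction favoured. Compound 4 is expected at 7000 nM with an estimated range from 3500 nM to 14000 nM on this read-out.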

Compound 4, half-maximal inhibitory concentration: 5810 nM
Beside the measured number, compound 4's estimate is 1.2-fold (0.08 log units) above it, and the stated range covers the measured number.
By their numbers in this assay, from the lowest: compounds 2, 4 and 1 (each within the scatter of the next); then compound 3.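

For the compounds shown here, compound 1 and compound 4 form the first pair in this assay that differs in one place: diethylamino in place of pyrrolidin-1-yl on a saturated chain carbon bound to an aromatic carbon gives a 1.2-fold lower number from compound 1 to compound 4 (0.09 log units; within the scatter). At this position, then, the ring of pyrrolidin-1-yl can be opened without a change beyond the scatter. Nothing measured here accounts for this result.

Open, going by these compounds, is whether morpholin-4-yl, dimethylamino or a primary amine at the same place would read alike. Also open, on these data alone, is whether the same exchange holds on a different core.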